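Swapping isopropoxycarbonyl for 2,2,2-trifluoroethyl

The source may hold more compounds than are shown below. What is called first, only, known or untested is meant among the compounds shown, and "the series" means these compounds.

In a physicochemical assay for lipophilicity, read by HPLC (on this read-out lower numbers stand for lower lipophilicity and higher numbers for higher lipophilicity), compound 1 `CCOC(=O)c1ccccc1C(=O)N1C[C@H](Oc2cc(C#N)ccn2)CC[C@H]1C` gives 3.2 and compound 2 `CC(C)OC(=O)c1ccccc1C(=O)N1C[C@H](Oc2cc(C#N)ccn2)CC[C@H]1C` gives 3.6 as the higher of the two numbers. Compound 3 `C[C@@H]1CC[C@@H](Oc2cc(C#N)ccn2)CN1C(=O)c1ccccc1CC(F)(F)F` differs from compound 2 at one place, with 2,2,2-trifluoroethyl in place of isopropoxycarbonyl on an aromatic carbon, and 2,2,2-trifluoroethyl in place of isopropoxycarbonyl on an aromatic carbon sets out that change. Within the data shown here, the only measured step is a number 0.40 log units higher from compound 1 to compound 2 (beyond the scatter) and it is modest, touching just part of the group that leaves, so it is a rough guide only. No step beyond the scatter is expected, with a number 0.20 log units lower from compound 2 to compound 3 (within the scatter) as the estimate. In this assay the estimate for compound 3 is 3.4 in an expected range from 2.9 to 3.9 for this measurement.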

Compound 3, distribution coefficient: 3.6
Compound 3: the middle estimate sits 0.20 log units below what was measured; low and high end bracket the measured number.
By their numbers in this assay, from the lowest: compound 1; then compounds 2 and 3 (each within the scatter of the next).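

On an aromatic carbon ortho to a large group, replacing isopropoxycarbonyl with 2,2,2-trifluoroethyl, a group with no hydrogen-bond acceptors, gives no change at the digits printed from compound 2 to compound 3 (within the scatter) in this assay. The same group in place of ethoxycarbonyl gives a number 0.40 log units higher from compound 1 to compound 3 (beyond the scatter), so at this position the two replacements differ in outcome. No evidence here explains either result. The compounds shown leave open how a plain ethyl chain, an amine or a carboxylic acid at this position would read in this assay. They also leave open whether the match between compound 2 and compound 3 extends to any other property.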